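Removing the nitro group from compound 3

This account rests on a few compounds, and the source may have more. Where it says the series, first, only, none or still open, it means among the compounds named here.

Among the measured compounds shown here, in an ADME assay on MDBK cells (Bos taurus) for cytotoxicity, read by MTT assay, with a stated time of 96 h (a lower number here means that less compound is tolerated, a higher number that more compound is tolerated), compound 1 `COc1ccc(/N=N/N2CCCC2)cc1` gives 60000 nM, the only true number in this small series. Compound 2 `FC(F)(F)c1cccc(/N=N/N2CCCC2)c1` reads > 100000 nM, which is a limit of the assay and not a number. On these data alone, compound 3 `O=[N+]([O-])c1cccc(/N=N/N2CCCC2)c1` reads > 100000 nM, which is again only a limit, so its true value stays unknown. The series therefore gathers at the limit of > 100000 nM in this assay, at which 2 of the 3 values shown sit, and that is where compound 3 stands.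

Compound 4 `c1ccc(/N=N/N2CCCC2)cc1` differs from compound 3 in one place, with hydrogen in place of nitro on an aromatic carbon. For the measured compounds named here, the one measured step that touches the nitro group is a step that the two limits leave unreadable from compound 2 to compound 3, and it offers no size to carry over. Going by the values given here, the only guide to a real number is compound 1 at 60000 nM, which shows that a compound of this series can give a measured number. A modest move toward less compound tolerated is therefore expected, if the step can be read at all, and it is estimated as an at least 1.1-fold lower number from compound 3 to compound 4 (0.04 log units; that floor lies within the scatter). The estimate for compound 4 is 90000 nM, with an expected range from 45000 nM to 180000 nM.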

Compound 4, half-maximal cytotoxic concentration: > 100000 nM
Compound 4 was reported as a limit; the forecaster's own chance of this, stated with the estimate: 45%; middle value at least 1.1-fold (0.04 log units) from the limit.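

Compound 4 gives a limit of the assay and not a number, so it joins the cluster at the top of the series: the limit of > 100000 nM in this assay, at which 3 of the 4 values shown sit. This shows that the nitro group is not needed for this reading: with only hydrogen on that aromatic carbon, the reading in this assay is the same limit, although the steps linking compound 4 to compound 2 and compound 3 run between two limits and cannot be read. The new compound also gives the series its first step with a size, an at least 1.6-fold higher number from compound 1 to compound 4 (0.22 log units; that floor lies within the scatter), but this is only a floor, so it does not establish a real difference between methoxy and hydrogen.

On these data alone, how far the true values of compound 2, compound 3 and compound 4 lie beyond the limit stays open, so these three cannot be ranked against one another. Also open, as far as these compounds go, is whether an amine or a carboxylic acid on this aromatic carbon would bring the reading down to a true number, as compound 1 with its methoxy group gives.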